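Removing a Methoxy Group: Expected Effect on Cell Killing

The source may report more compounds than this note shows. Statements on the series, on what has been measured and on what is new or still open speak of the compounds shown alone.

compound 1, `COc1ccc(-c2nc(-c3ccccc3)c(-c3ccc4c(c3)NC(=O)CO4)[nH]2)cc1`: 19.1%
compound 2, `COc1ccc(-n2cc(-c3ccccc3)c(-c3ccc4c(c3)NC(=O)CO4)n2)cc1`: 35.6%
compound 3, `O=C1COc2ccc(-c3nn(-c4ccc(Br)cc4)cc3-c3ccccc3)cc2N1`: 54.2%

In a functional assay on DLD-1 cells (Homo sapiens) for cytotoxicity, read by colorimetric assay and MTT assay, with a stated time of 3 days, tested at 20 uM (a higher number here means a weaker effect of the compound at the concentration tested, a lower number a stronger effect), compound 1 gives the lowest of the three numbers, the strongest effect shown; compound 2 lies higher by more than the scatter, and compound 3 higher still. Compound 4 `O=C1COc2ccc(-c3[nH]c(-c4ccccc4)nc3-c3ccccc3)cc2N1` differs from compound 1 by hydrogen in place of methoxy on an aromatic carbon. Within the data shown here, the only measured step at a comparable position is a number 18.6 percentage points higher from compound 2 to compound 3 (beyond the scatter), a modest weakening, but it exchanges methoxy for bromo rather than for hydrogen, so it bears only loosely here. Losing the methoxy is therefore expected to weaken the effect modestly, a number 12.9 percentage points higher from compound 1 to compound 4 (beyond the scatter). Compound 4 is estimated at 32%, with a range from 15% to 52%.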

Compound 4, a percentage reported as activity, at one concentration (the size of the read-out at that concentration, not a potency): 47.3%
Compound 4: the middle estimate sits 15.3 percentage points below what was measured, within the range that was stated.
By their numbers in this assay, from the lowest: compound 1; then compound 2; then compounds 4 and 3 (each within the scatter of the next).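

Replacing the methoxy with hydrogen, the change from 4-methoxyphenyl to phenyl, gives in this assay a number 28.2 percentage points higher from compound 1 to compound 4 (beyond the scatter). Among these compounds, this is the first direct view of removing the group outright, whereas the earlier step exchanged it for bromo on a different core, and here the methoxy-bearing compound shows the stronger effect. No measurement at hand gives a reason for this step.

Going by these compounds, whether an amine, a hydroxyl or a longer chain such as ethoxy at this place would match the methoxy stays open. So does whether removing the methoxy from compound 2 would produce a similar step.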